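The compounds below may be only part of what the source reports. "The series", "measured", "known", "first", "only" and "open" are said of these compounds alone.

Compound 3 `O=[N+]([O-])c1ccc(CN(Cc2ccc(Cl)cc2)CC2CCN(Cc3ccccc3)C2)s1` has no single number in a functional assay on HEK293 cells for agonist activity at nuclear receptor subfamily 1 group D member 1 (Homo sapiens), read by a luciferase reporter, with a stated time of 24 h; a higher number here means that more compound is needed for the effect, a lower number that less compound is needed: for compound 3 the entry reads "not determined" (no result reported), and for compound 1 `CC(C)(C)OC(=O)CN(Cc1ccncc1)Cc1ccc(Cl)cc1` it likewise reads "not determined" (no result reported). Among the measured compounds shown here, the only number in the set comes from compound 2 `O=C(c1cccc2ccccc12)N(Cc1ccc(Cl)cc1)Cc1ccc([N+](=O)[O-])s1`, which gives 2600 nM in this assay, but no step links compound 2 to compound 3, so compound 3 stands without a measured anchor. Compound 4 `O=[N+]([O-])c1ccc(CN(Cc2ccc(Cl)cc2)CC2CCN(S(=O)(=O)Cc3ccccc3)C2)s1` differs from compound 3 in one place: benzylsulfonyl in place of benzyl on an amine nitrogen in a ring. For the measured compounds named here, with no measured step across this change, no direction can be drawn from the data; the step could fall within the scatter or beyond it in either direction. Going by the values given here, on the single reported number alone, compound 4 is estimated at 3000 nM, expected to lie between 600 nM and 15000 nM.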

Compound 4, half-maximal effective concentration: 630 nM
Compound 4: the middle estimate sits 4.8-fold (0.68 log units) above what was measured; the range from low to high includes it.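

Among the compounds shown here, compound 3 has no single number in this assay and so no step to compound 4 can be read. As far as these compounds go, whether benzylsulfonyl in place of benzyl shifts the value stays open, and no evidence at hand bears on this result.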